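The source may report more compounds than this note shows. Statements on the series, on what has been measured and on what is new or still open speak of the compounds shown alone.

Measured so far in a functional assay on HCT-116 cells (Homo sapiens) for cytotoxicity, read by MTT assay, with a stated time of 72 h; on this read-out higher numbers stand for weaker inhibition and lower numbers for stronger inhibition
compound 1 `O=C1C=CCC/C1=C\C=C\c1ccccc1` gives 5400 nM
compound 2 `Cc1ccc(/C=C/C=C2\CCC=CC2=O)cc1` gives 7200 nM
compound 3 `O=C1C=CCC/C1=C\C=C\c1ccc(Cl)cc1` gives 3500 nM

Compound 3 stands level with compound 1 within the scatter, as a 1.5-fold lower number from compound 1 to compound 3 (0.19 log units; within the scatter) shows. Among the compounds with values here, it separates only from compound 2, with a 2.1-fold lower number from compound 2 to compound 3 (0.31 log units; beyond the scatter) as the one step beyond the scatter.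

Compound 4 `O=C1C=CCC/C1=C\C=C\c1ccc(Br)cc1` has bromo in place of chloro on an aromatic carbon of compound 3, with bromo in place of chloro on an aromatic carbon as the counted difference. Within the data shown here, no bromo compound has been measured, so the evidence comes only from the other swaps on the aromatic carbon. Of these, a 1.3-fold higher number from compound 1 to compound 2 (0.12 log units; within the scatter) also stays inside the scatter, and the chloro steps above are small or modest. No step beyond the scatter, in either direction, is therefore expected in this assay for this swap. The estimated step is a 1.1-fold lower number from compound 3 to compound 4 (0.03 log units; within the scatter) as the working expectation. The estimate for compound 4 is 3300 nM with an expected range from 1800 nM to 6000 nM on this read-out.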

Compound 4, half-maximal inhibitory concentration: 5200 nM
For compound 4 the middle estimate is 1.6-fold (0.20 log units) below the measured one, and the stated range covers the measured number.
By their numbers in this assay, from the lowest: compounds 3, 4, 1 and 2 (each within the scatter of the next, the first and the last beyond it).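

In this assay, bromo on the aromatic carbon para to a large group stands level with each of the other three groups tested there: bromo in place of chloro gives a 1.5-fold higher number from compound 3 to compound 4 (0.17 log units; within the scatter), bromo in place of methyl gives a 1.4-fold lower number from compound 2 to compound 4 (0.14 log units; within the scatter), and bromo in place of hydrogen gives a 1.0-fold lower number from compound 1 to compound 4 (0.02 log units; within the scatter). Within the data shown here, compound 4 therefore separates from none of them, so the only step beyond the scatter at this position remains a 2.1-fold lower number from compound 2 to compound 3 (0.31 log units; beyond the scatter), and bromo does not share the separation from methyl seen for chloro. No measurement bearing on this result is available to explain it.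

Going by these compounds, all three steps away from the hydrogen of compound 1 lie within the scatter, so it remains open whether any group at this position can move the number beyond it. An amine or a carboxylic acid in the same place would test this.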